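Ethyl in Place of Fluoro: An Expected Potency

The source may report more compounds than this note shows. Statements on the series, on what has been measured and on what is new or still open speak of the compounds shown alone.

Three measured compounds:
In an assay on mitochondria from L6 cells (Rattus norvegicus) for activation, with a stated time of 90 min (a lower number here means that less compound is needed, a higher number that more compound is needed for the effect), compound 1 `COc1cccc(Nc2nc3nonc3nc2O)c1` gives 75400 nM.
In this assay compound 2 `Oc1nc2nonc2nc1Nc1cccc(S(F)(F)(F)(F)F)c1` gives 3700 nM.
In this assay compound 3 `Oc1nc2nonc2nc1Nc1cccc(F)c1` gives 31200 nM.

Compound 3 holds the second highest number of the three: a 2.4-fold lower number from compound 1 to compound 3 (0.38 log units; beyond the scatter), while an 8.4-fold higher number from compound 2 to compound 3 (0.93 log units; beyond the scatter). Compound 4 `CCc1cccc(Nc2nc3nonc3nc2O)c1` differs from compound 3 in one place: ethyl in place of fluoro on an aromatic carbon. Among the compounds with values here, no measured step puts ethyl in place of fluoro. Within the data shown here, the steps that bear on it show that the group on this aromatic carbon matters: a 20-fold lower number from compound 1 to compound 2 (1.31 log units; beyond the scatter), a large change, whereas fluoro in place of methoxy gave only a modest one. Ethyl has no measured precedent here, so only a small shift is expected: a 1.6-fold lower number from compound 3 to compound 4 (0.19 log units; within the scatter). Compound 4 is therefore estimated at 20000 nM, within 6000 nM to 60000 nM.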

Compound 4, half-maximal effective concentration: 25200 nM
Compound 4: middle estimate off by 1.3-fold (0.10 log units), on the low side; the range from low to high includes it.
By their numbers in this assay, from the lowest: compound 2; then compounds 4 and 3 (each within the scatter of the next); then compound 1.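

Fluoro and ethyl on this aromatic carbon cannot be told apart, with a 1.2-fold lower number from compound 3 to compound 4 (0.09 log units; within the scatter) as the step between them. Ethyl is still separated from the other two groups, with a 6.8-fold higher number from compound 2 to compound 4 (0.83 log units; beyond the scatter) and a 3.0-fold lower number from compound 1 to compound 4 (0.48 log units; beyond the scatter) as its steps, so the group here matters, though not for this swap. No measured evidence explains these differences. From the compounds shown here alone, it remains open where a longer chain such as propyl, an amine or a carboxylic acid would fall on this carbon. Going by these compounds, whether the same groups behave alike elsewhere on the ring also remains open.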